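A few compounds are considered here, and "the series" means these few. Any claim that something is new, unique, unknown or untested is made for them only; others in the source may bear on it.

In an ADME assay on cells (Splenocyte, Mus musculus, strain BALB/c) for cytotoxicity, read by thymidine incorporation, with a stated time of 24 h (a higher number here means a weaker inhibitor, a lower number a stronger inhibitor), compound 1 `O=C(CCN1CCN(c2ccnc3cc(Cl)ccc23)CC1)N/N=C/c1ccccc1` gives 300 nM and compound 2 `O=C(CCN1CCN(c2ccnc3cc(Cl)ccc23)CC1)N/N=C/c1ccc([N+](=O)[O-])cc1` gives 12100 nM, which amounts to a 40-fold higher number from compound 1 to compound 2 (1.61 log units; beyond the scatter). Compound 3 `NNC(=O)CCN1CCN(c2ccnc3cc(Cl)ccc23)CC1` is reported only as > 100000 nM, which is a limit of the assay and not a number. Compound 4 `O=C(CCN1CCN(c2ccnc3cc(Cl)ccc23)CC1)N/N=C/c1ccc(Cl)cc1` has not yet been measured. The structural change is a group of 9 heavy atoms (7 carbon, 1 nitrogen, 1 chlorine; one six-membered aromatic ring of carbon only) in place of one nitrogen atom, on an amide-type nitrogen, so a group with one six-membered aromatic ring of carbon only and a chlorine enters on the amide-type nitrogen. Among the measured compounds shown here, two measured steps bear on this, and they run the same kind of change in the opposite sense: an at least 330-fold higher number from compound 1 to compound 3 (2.52 log units; beyond the scatter) and an at least 8.2-fold higher number from compound 2 to compound 3 (0.91 log units; beyond the scatter). The first is large and the second at least modest, and both lie beyond the scatter. A clear move back towards a lower number, meaning a stronger inhibitor in this assay, is therefore expected. The expected size is an at least 50-fold lower number from compound 3 to compound 4 (1.69 log units; beyond the scatter). For compound 4 the estimated value is 2000 nM, with an expected range from 250 nM to 15000 nM.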

Compound 4, half-maximal inhibitory concentration: 200 nM
The estimate for compound 4 lay 10-fold (1.00 log units) above the measured number; measured number below the stated range.
By their numbers in this assay, from the lowest: compounds 4 and 1 (each within the scatter of the next); then compound 2. At a limit, above all of these: compound 3.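

Chloro in place of hydrogen on the aromatic carbon brings no change beyond the scatter in this assay, a 1.5-fold lower number from compound 1 to compound 4 (0.18 log units; within the scatter), which shows that this carbon can carry a substituent without the shift seen with nitro. The step of a 61-fold lower number from compound 2 to compound 4 (1.78 log units; beyond the scatter) shows that the higher number of compound 2 goes with nitro specifically, not with any substituent there. The step of an at least 500-fold lower number from compound 3 to compound 4 (2.69 log units; beyond the scatter) is read against a limit of the assay for compound 3 and shows that the chloro-bearing group on the amide-type nitrogen matches the effect of the unsubstituted one: the limit of > 100000 nM in this assay, at which 1 of the 4 values shown sits.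

On these data alone, whether an amine or a methoxy group on that aromatic carbon would behave like chloro or like nitro stays open. So does whether a saturated ring or a longer chain could replace the aromatic group on the amide-type nitrogen.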